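A few compounds are considered here, and "the series" means these few. Any claim that something is new, unique, unknown or untested is made for them only; others in the source may bear on it.

Compounds measured in a functional assay on HCT-116 cells (Homo sapiens) for inhibition, read by sulforhodamine B assay, with a stated time of 48 h; on this read-out lower numbers stand for stronger inhibition of growth and higher numbers for weaker inhibition of growth:
compound 1 `COc1cc2cc(Oc3ccc(NC(=O)Nc4cccc(C(F)(F)F)c4)cc3)c(C)nc2cc1OC` with 1460 nM
compound 2 `COc1cc2cc(Oc3ccc(NC(=O)Nc4ccc(Cl)c(C(F)(F)F)c4)cc3)c(C)nc2cc1OC` with 994 nM

Within the data shown here, compound 2 gives the lowest of the two numbers, its only neighbour being compound 1, and the step of a 1.5-fold lower number from compound 1 to compound 2 (0.17 log units; within the scatter) stays within the scatter, so no order between the two can be claimed. Compound 3 `COc1cc2cc(Oc3ccc(NC(=O)Nc4ccc(Cl)c(Cl)c4)cc3)c(C)nc2cc1OC` has not yet been measured. It differs from compound 2 by chloro in place of trifluoromethyl on an aromatic carbon. Among the measured compounds shown here, only one measured step sits on the same ring, a 1.5-fold lower number from compound 1 to compound 2 (0.17 log units; within the scatter), and it was within the scatter; no measured pair exchanges trifluoromethyl for chloro, so the expectation rests on that single small step and on the modest size of the change. The step expected in this assay is therefore a 1.4-fold higher number from compound 2 to compound 3 (0.15 log units; within the scatter), with no direction claimed beyond the scatter. For compound 3 the estimated value is 1400 nM, within 550 nM to 3600 nM.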

Compound 3, concentration for 50% growth inhibition: 2260 nM
The estimate for compound 3 lay 1.6-fold (0.21 log units) below the measured number; low and high end bracket the measured number.
By their numbers in this assay, from the lowest: compounds 2, 1 and 3 (each within the scatter of the next, the first and the last beyond it).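

In this assay, among these compounds, the exchange of trifluoromethyl for chloro, ortho to a chloro group, gives a 2.3-fold higher number from compound 2 to compound 3 (0.36 log units; beyond the scatter) and is the first step to pass the scatter, so this position does register which group it carries, though only modestly. The difference appears only with the other chloro group in place: a 1.5-fold higher number from compound 1 to compound 3 (0.19 log units; within the scatter) leaves 3,4-dichlorophenyl and 3-(trifluoromethyl)phenyl without an order. No evidence available here accounts for the step.

From the compounds shown here alone, whether an amine, a carboxylic acid or a methoxy group at this position would move the number further, and in which direction, stays open. Also open, going by these compounds, is whether the exchange of trifluoromethyl for chloro gives a similar step on a ring lacking the other chloro group.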